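A Chloro Substituent on the Far Phenyl Ring

This account rests on a few compounds, and the source may have more. Where it says the series, first, only, none or still open, it means among the compounds named here.

Compound 2 `O=C(/C=C/c1cccc(O)c1)c1cccc(-n2cc(-c3ccccc3)[nH]c2=O)c1` gives 11100 nM in a functional assay on SK-OV-3 cells (Homo sapiens) for inhibition (on this read-out higher numbers stand for weaker inhibition of growth and lower numbers for stronger inhibition of growth), the higher of the two numbers measured; compound 1 `COc1cc(/C=C/C(=O)c2cccc(-n3cc(-c4ccccc4)[nH]c3=O)c2)ccc1O` gives 3760 nM. For the measured compounds named here, the one measured step, a 3.0-fold higher number from compound 1 to compound 2 (0.47 log units; beyond the scatter), concerns the ring on the chain and so does not bear on the change considered now. Compound 3 `O=C(/C=C/c1cccc(O)c1)c1cccc(-n2cc(-c3ccc(Cl)cc3)[nH]c2=O)c1` differs from compound 2 by chloro in place of hydrogen on an aromatic carbon. Going by the values given here, with no measured step to guide it, the expected change is small, and the estimated step of a 1.4-fold lower number from compound 2 to compound 3 (0.14 log units; within the scatter) leans toward none beyond the scatter. Compound 3 is therefore expected to give about 8000 nM, within 3000 nM to 25000 nM.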

Compound 3, concentration for 50% growth inhibition: 4210 nM
The estimate for compound 3 lay 1.9-fold (0.28 log units) above the measured number, within the range that was stated.
By their numbers in this assay, from the lowest: compounds 1 and 3 (each within the scatter of the next); then compound 2.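

Changing phenyl to 4-chlorophenyl gives a 2.6-fold lower number from compound 2 to compound 3 (0.42 log units; beyond the scatter) in this assay, so the far phenyl ring, and not only the ring on the chain, bears on growth inhibition. A single chlorine atom is enough for a modest step in the direction of stronger inhibition. Nothing measured here accounts for this step.

As far as these compounds go, whether the chloro gives a similar step alongside the 4-hydroxy-3-methoxyphenyl of compound 1 remains open. So does the outcome of placing a fluoro, a methoxy or an amine on the same aromatic carbon.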